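This account rests on a few compounds, and the source may have more. Where it says the series, first, only, none or still open, it means among the compounds named here.

Working notes on the series. In an assay on L cells for inhibition of Protein-serine O-palmitoleoyltransferase porcupine (Mus musculus), read by reporter gene assay, with a stated time of 24 h (on this read-out higher numbers stand for an effect only at larger amounts of compound and lower numbers for an effect already at smaller amounts), compound 1 `COc1ccccc1-n1c(SCC(=O)Nc2nc3ccc(C(F)(F)F)cc3s2)nc2c(c1=O)SCC2` gives 30 nM, compound 2 `O=C(CSc1nc2c(c(=O)n1-c1ccccc1)SCC2)Nc1nc2ccc(C(F)(F)F)cc2s1` gives 40 nM, and compound 3 `COc1ccc(-n2c(SCC(=O)Nc3nc4ccc(OC)cc4s3)nc3c(c2=O)SCC3)cc1` gives 120 nM. The difference between the cores of compound 1 and compound 3 is not broken down here. Compound 2 comes from compound 1 by hydrogen in place of methoxy on an aromatic carbon, a change that made a 1.3-fold higher number from compound 1 to compound 2 (0.12 log units; within the scatter). Compound 4 `COc1ccc2nc(NC(=O)CSc3nc4c(c(=O)n3-c3ccccc3)SCC4)sc2c1` is not yet measured; it comes from compound 3 by hydrogen in place of methoxy on an aromatic carbon. This is the same kind of change, though in compound 1 the methoxy sits ortho to a large group and in compound 3 it sits para to a large group. Because the earlier step of a 1.3-fold higher number from compound 1 to compound 2 (0.12 log units; within the scatter) stayed within the scatter, a step of about the same size is expected, a 1.2-fold higher number from compound 3 to compound 4 (0.07 log units; within the scatter). Compound 4 is estimated at 140 nM, between 60 nM and 330 nM.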

Compound 4, half-maximal effective concentration: 40 nM
The estimate for compound 4 lay 3.5-fold (0.54 log units) above the measured number, outside the stated range (below it).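

Hydrogen in place of methoxy gives a 3.0-fold lower number from compound 3 to compound 4 (0.48 log units; beyond the scatter), so in this assay this change does not carry over as one fixed step from one core to the other: the same change on two cores in this assay, a 1.3-fold higher number (0.12 log units; within the scatter) from compound 1 to compound 2 and a 3.0-fold lower number (0.48 log units; beyond the scatter) from compound 3 to compound 4, 4.0-fold (0.60 log units) apart, beyond the scatter of two such steps
Methoxy in place of trifluoromethyl reads no change at the digits printed from compound 2 to compound 4 (within the scatter), so these two groups are not told apart in the compounds that carry phenyl. The two pairs show that the step depends on its surroundings but not what sets the difference, since the methoxy also sits in a different place in each pair, and one pair per core gives no rule for a further core.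

Left open is how a chlorine atom or an amine on that phenyl ring would behave on either core. Also open, as far as these compounds go, is whether a compound joining 4-methoxyphenyl with trifluoromethyl would stand closer to compound 1 or compound 3.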